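Ethyl ester of compound 1: an expected step

A few compounds are considered here, and "the series" means these few. Any claim that something is new, unique, unknown or untested is made for them only; others in the source may bear on it.

compound 1 `CCOc1ccccc1-c1ncc(C(=O)O)c(=O)[nH]1`: 0.5 mg/kg
compound 2 `CC(C)COc1ccccc1-c1ncc(C(=O)O)c(=O)[nH]1`: 0.5 mg/kg

In a functional assay on the whole organism (strain Sprague-Dawley) for inhibition, with Rattus norvegicus as the target, with a stated time of 10 min (a higher number here means that more compound is needed for the effect, a lower number that less compound is needed), compound 1 gives 0.5 mg/kg, level with compound 2 at 0.5 mg/kg. Compound 3 `CCOC(=O)c1cnc(-c2ccccc2OCC)[nH]c1=O` has not yet been measured. It departs from compound 1 at the carboxy group, carboxy to ethoxycarbonyl: ethyl in place of hydrogen on an oxygen next to a carbonyl group. Among the measured compounds shown here, the one measured step is no change at the digits printed from compound 1 to compound 2 (within the scatter). It lies on a saturated chain carbon bound to an oxygen on an aromatic ring, away from this change, so it says little here. For the measured compounds named here, no measured step covers the carboxy group, and the size of the change remains uncertain. A higher dose in this assay is expected, though only tentatively. The estimated step is an 8.0-fold higher number from compound 1 to compound 3 (0.90 log units; beyond the scatter). For compound 3 the expected value is 4 mg/kg. The estimated range for compound 3 runs from 0.7 mg/kg to 25 mg/kg.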

Compound 3, dose for 50% inhibition: 2 mg/kg
Compound 3: middle estimate off by 2.0-fold (0.30 log units), on the high side, within the range that was stated.
By their numbers in this assay, from the lowest: compounds 1 and 2 (each within the scatter of the next); then compound 3.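

Ethyl in place of hydrogen on the oxygen next to a carbonyl group gives a 4.0-fold higher number from compound 1 to compound 3 (0.60 log units; beyond the scatter) in this assay. The earlier pair changed only a saturated chain carbon bound to an oxygen on an aromatic ring and gave no change at the digits printed from compound 1 to compound 2 (within the scatter); this result shows that the carboxy group is a place where a change can move the dose beyond the scatter, while the ethoxycarbonyl compound still gives a dose for half inhibition. Nothing given here accounts for the shift.

The compounds shown leave open how other groups at this place would read, such as a methyl ester, a primary amide or a longer ester chain. They also leave open whether the same change on compound 2 would give a step of similar size.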